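A few compounds are considered here, and "the series" means these few. Any claim that something is new, unique, unknown or untested is made for them only; others in the source may bear on it.

Working notes on the series.

Compound 3 `Brc1ccc2ccn(CCN3CCCN(CC4CC4)CC3)c2c1` in an assay on HEK293 cells for binding affinity to 5-hydroxytryptamine receptor 7 (Homo sapiens), read by radioligand binding, tested at 1 uM (on this read-out higher numbers stand for more inhibition at the one concentration tested (going by the name of the read-out) and lower numbers for less inhibition), gives 95%. Compound 2 `CC(C)CN1CCCN(CCn2ccc3ccc(Br)cc32)CC1` in this assay gives 95%, and compound 1 `CN1CCCN(CCn2ccc3ccc(Br)cc32)CC1` in this assay gives 93%. Compound 3 stands level with compound 2 at the digits shown, and the pair carry the two largest numbers of the three; compound 1 is furthest off, yet the step of a number 2 percentage points higher from compound 1 to compound 3 (within the scatter) lies within the scatter, so the three values are not separated.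

Compound 4 `Brc1ccc2ccn(CCN3CCCN(C4CCCC4)CC3)c2c1` differs from compound 3 in one place: cyclopentyl in place of cyclopropylmethyl on an amine nitrogen in a ring

Among the measured compounds shown here, three measured steps touch the group on this ring nitrogen. The step of a number 2 percentage points higher from compound 1 to compound 2 (within the scatter) and the step of a number 2 percentage points higher from compound 1 to compound 3 (within the scatter) both add a small saturated group where hydrogen stood, and the step of no change at the digits printed from compound 2 to compound 3 (within the scatter) exchanges one such group for another; none moves beyond the scatter. Each is a change of the substituent on the same amine nitrogen in a ring, so they bear on the present change directly, though none of them reaches a cyclopentyl.

Given the flatness of no change at the digits printed from compound 2 to compound 3 (within the scatter), the step of a number 1 percentage points lower from compound 3 to compound 4 (within the scatter) is expected to stay within the scatter, in no firm direction. Compound 4 is therefore estimated at 94%, with a range from 86% to 99%.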

Compound 4, a percentage reported as inhibition, at one concentration (the size of the read-out at that concentration, not a potency): 98%
Compound 4: middle estimate off by 4 percentage points, on the low side; the range from low to high includes it.
By their numbers in this assay, from the lowest: compounds 1, 2, 3 and 4 (each within the scatter of the next).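

The ring nitrogen also accepts a substituent whose ring is bound to it with no chain carbon in between: a number 3 percentage points higher from compound 3 to compound 4 (within the scatter) when cyclopentyl replaces cyclopropylmethyl, and a number 3 percentage points higher from compound 2 to compound 4 (within the scatter) when it replaces isobutyl. Even the largest difference among the four compounds, a number 5 percentage points higher from compound 1 to compound 4 (within the scatter) when cyclopentyl replaces methyl, does not separate them in this assay and so gives this position no order among the groups shown. No measurement available here accounts for these values or for any effect of the cyclopentyl ring.

Open, going by these compounds, is whether a six-membered carbocycle such as cyclohexyl, a benzyl group or a chain ending in a carboxylic acid on this ring nitrogen would move the value beyond the scatter, or whether the position stays as flat as it does across methyl, isobutyl, cyclopropylmethyl and cyclopentyl. Also open, on these data alone, is how these four compounds would differ at lower concentrations, since a reading at one concentration gives no potency, and what a change to the shared core would do.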